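The compounds below may be only part of what the source reports. "The series", "measured", "known", "first", "only" and "open" are said of these compounds alone.

In a functional assay on QGY cells (Homo sapiens) for cytotoxicity, read by MTT assay, with a stated time of 48 h (a higher number here means a weaker inhibitor, a lower number a stronger inhibitor), compound 1 `CCOC(=O)[C@@]1(C(=O)Nc2ccccc2)C[C@@H]1c1cc(OC)c(OC)c(OC)c1` gives > 100000 nM, which is a limit of the assay and not a number. Compound 2 `CCOC(=O)[C@@]1(C(=O)Nc2ccccc2Cl)C[C@@H]1c1cc(OC)c(OC)c(OC)c1` gives > 100000 nM, again a limit. Compound 3 `COc1cc([C@H]2C[C@@]2(CO)C(=O)Nc2ccccc2Cl)cc(OC)c1OC` gives > 100000 nM, also a limit. Compound 2 thus stands on (the limit of > 100000 nM in this assay, at which 3 of the 3 values shown sit), with no measured number to start from.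

Compound 4 `CCOC(=O)[C@@]1(C(=O)Nc2ccccc2Cl)C[C@H]1c1cc(OC)c(OC)c(OC)c1` relates to compound 2 as follows: the two compounds have the same atoms and bonds and differ only in configuration as drawn: 1 of 2 stereo elements differ; a stereocentre at a saturated ring carbon is drawn R in compound 2 and S in compound 4. Among the compounds with values here, two measured steps bear on this change, though only loosely. Chloro in place of hydrogen on an aromatic carbon is a step that the two limits leave unreadable from compound 1 to compound 2, and hydroxymethyl in place of ethoxycarbonyl on a saturated ring carbon is a step that the two limits leave unreadable from compound 2 to compound 3. Neither step has a readable size, and neither involves a change of configuration.

The nearest guide is compound 2, whose limit is > 100000 nM. The expected outcome is a number no higher from compound 2 to compound 4 (the limit leaves the size open), with no direction that the data can support. Estimated for compound 4 is 100000 nM, expected to lie between 30000 nM and 300000 nM, and most likely to be reported as a limit again.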

Compound 4, half-maximal inhibitory concentration: 34300 nM
The estimate for compound 4 lay 2.9-fold (0.46 log units) above the measured number; the range from low to high includes it.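

Changing one stereocentre at a saturated ring carbon, from R as drawn to S, gives in this assay an at least 2.9-fold lower number from compound 2 to compound 4 (0.46 log units; beyond the scatter). The size is only a minimum, as the value for compound 2 is a limit of the assay, but this is the one step shown that can be read, and compound 4 is the only compound here to give a measured number rather than the shared limit: the limit of > 100000 nM in this assay, at which 3 of the 4 values shown sit. The arrangement in space at this carbon therefore matters for this read-out, and the change can be pinned on that one stereocentre: the fact that compounds 2 and 4 differ only in the configuration as drawn.

From the compounds shown here alone, the two earlier steps cannot be read, so it remains open whether chloro or ethoxycarbonyl contributes to the value of compound 4 when the stereocentre is drawn S. Also open is how that form would respond if a carboxylic acid or a longer ester chain replaced the ethoxycarbonyl group.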